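The source may hold more compounds than are shown below. What is called first, only, known or untested is meant among the compounds shown, and "the series" means these compounds.

The measured compounds so far:

Compound 1, `CCOC(=O)CCCCCOc1cccc(CN(C(=O)c2ccc(-c3cnc(OC)nc3OC)cc2)C(C)C)c1`, in an ADME assay on HEK293 cells (Homo sapiens) for cytotoxicity, read by CellTiter-Glo and resazurin assay, with a stated time of 72 h (on this read-out higher numbers stand for an effect only at larger amounts of compound and lower numbers for an effect already at smaller amounts), gives > 26000 nM.
Compound 2, `CCOC(=O)CCCCCOc1cccc(CN(C(=O)c2ccc(-c3ccc(C(C)=O)s3)cc2)C(C)C)c1`, in this assay gives > 26000 nM.

Both of these values are limits of the assay, not numbers: the read-out for compound 1 stops at the limit, and the read-out for compound 2 stops at the same limit. Among the measured compounds shown here, the single step between them, a step that the two limits leave unreadable from compound 1 to compound 2, therefore cannot be sized, and the only firm point is the limit of > 26000 nM in this assay, at which 2 of the 2 values shown sit.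

Compound 3 is `CCOC(=O)CCCCCOc1cccc(CN(C(=O)c2ccc(-c3cccc(OC)c3)cc2)C(C)C)c1`. It differs from compound 2 by 3-methoxyphenyl in place of 5-acetylthiophen-2-yl on an aromatic carbon. For the measured compounds named here, the one measured step that bears on this change is unreadable, and both compounds sit at the limit, so no step beyond the scatter is expected in this assay from this change either. Compound 3 is therefore expected at 26000 nM, within a range of 13000 nM to 60000 nM, and the step from compound 2 is estimated as a number no higher from compound 2 to compound 3 (the limit leaves the size open).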

Compound 3, half-maximal effective concentration: > 21000 nM
Compound 3 ended at the assay's limit (the forecaster's own chance of this, stated with the estimate: 85%); the middle value does not contradict the limit.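

Among the compounds shown here, compound 1, compound 2 and compound 3 all end at limits of the assay, not at numbers, and no step among them can be read. Left open is the concentration at which any of them would reach a half-maximal effect in this assay, and whether exchanging these groups changes it at all.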